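Lengthening the Side Chain of Compound 1

The source may hold more compounds than are shown below. What is called first, only, known or untested is meant among the compounds shown, and "the series" means these compounds.

Compound 1, `C/C=C/C=C/CCc1cc(O)c([C@@H]2O[C@H](CO)[C@@H](O)[C@H](O)[C@H]2O)c(O)c1C(=O)OC`: > 40000 nM
Compound 2, `CCC/C=C\C=C\CCc1cc(O)c([C@@H]2O[C@H](CO)[C@@H](O)[C@H](O)[C@H]2O)c(O)c1`: 30000 nM
Compound 3, `CCC/C=C/C=C\CCc1cc(O)cc(O)c1`: 28000 nM

All three compounds were tested in a functional assay on RAW264.7 cells (Mus musculus) for inhibition, read by Griess assay, with stated times of 2 h and 12 h; on this read-out higher numbers stand for weaker inhibition and lower numbers for stronger inhibition. For compound 1 this assay reports only a limit, not a number, namely > 40000 nM. That reading is the limit of > 40000 nM in this assay, at which 1 of the 3 values shown sits. Compound 2 gives 30000 nM in this assay, and compound 3 gives 28000 nM; these two numbers lie within the usual scatter of each other, so neither can be called the stronger of the pair. Taken together, the three compounds show only weak inhibition in this assay.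

Compound 4, `CCC/C=C/C=C/CCc1cc(O)c([C@@H]2O[C@H](CO)[C@@H](O)[C@H](O)[C@H]2O)c(O)c1C(=O)OC`, is the next compound to be measured. It differs from compound 1 by ethyl in place of hydrogen on a saturated chain carbon bound to a double-bonded chain carbon. Within the data shown here, no pair of measured compounds differs by this same change, so there is no measured step to lean on. Because compound 1 sits at > 40000 nM, the starting point itself is only a limit. The step from compound 1 to compound 4 in this assay is expected to be a number no higher from compound 1 to compound 4 (the limit leaves the size open), that is, nothing beyond the scatter in either direction. Compound 4 is therefore expected to give about 40000 nM in this assay, within a range from 15000 nM to 100000 nM, and it may well again be reported only as a limit.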

Compound 4, half-maximal inhibitory concentration: > 40000 nM
Compound 4: no number, only a limit; the forecaster's own chance of this, stated with the estimate: 50%; the middle value lies on the limit itself.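

In this assay compound 4 is reported only as the limit > 40000 nM and not as a number. Among these compounds, no step from compound 1 to compound 4 can be read, because both compounds rest on the same limit: the limit of > 40000 nM in this assay, at which 2 of the 4 values shown sit. The compounds shown leave open whether ethyl in place of hydrogen on this saturated chain carbon changes inhibition at all.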